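This account rests on a few compounds, and the source may have more. Where it says the series, first, only, none or still open, it means among the compounds named here.

Working notes on the series in an ADME assay on HEK293 cells (Homo sapiens) for cytotoxicity, read by MTT assay, with a stated time of 72 h; a higher number here means a weaker inhibitor, a lower number a stronger inhibitor. Compound 1 `O=C(CN1CCN(C(=O)c2ccccc2)CC1)N1CCN(CCCc2c[nH]c3ccc(F)cc23)CC1` gives 148000 nM. Compound 2 `COc1ccc(C(=O)N2CCN(CC(=O)N3CCN(CCCc4c[nH]c5ccc(F)cc45)CC3)CC2)cc1` gives 141000 nM, and compound 3 `Cc1ccc(C(=O)N2CCN(CC(=O)N3CCN(CCCc4c[nH]c5ccc(F)cc45)CC3)CC2)cc1` gives 141000 nM. Compound 3 therefore stands level with compound 2 at the digits shown, and within the scatter of compound 1.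

The next structure is compound 4 `O=C(CN1CCN(C(=O)c2ccc(F)cc2)CC1)N1CCN(CCCc2c[nH]c3ccc(F)cc23)CC1`, which differs from compound 3 as follows: fluoro in place of methyl on an aromatic carbon. This is fluoro in place of methyl on an aromatic carbon, so that 4-methylphenyl becomes 4-fluorophenyl.

Among the compounds with values here, three measured steps bear on this change, all on the same ring. Adding a substituent gave a 1.0-fold lower number from compound 1 to compound 2 (0.02 log units; within the scatter) for methoxy and a 1.0-fold lower number from compound 1 to compound 3 (0.02 log units; within the scatter) for methyl, both within the scatter. Exchanging one substituent for the other gave no change at the digits printed from compound 2 to compound 3 (within the scatter), also within the scatter. Within the data shown here, no measured compound carries fluoro on this ring, so the estimate rests on these three steps alone. They give no direction to follow in this assay, and no step beyond the scatter is expected.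

The expected step is a 1.0-fold higher number from compound 3 to compound 4 (0.01 log units; within the scatter). Compound 4 is estimated at 143000 nM, with an expected range of 95000 nM to 210000 nM.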

Compound 4, half-maximal inhibitory concentration: 102000 nM
Compound 4: the middle estimate sits 1.4-fold (0.15 log units) above what was measured; the measured number falls inside the stated range.
By their numbers in this assay, from the lowest: compounds 4, 2, 3 and 1 (each within the scatter of the next).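

In this assay, fluoro is a new group at this place on the ring, on an aromatic carbon para to a large group, and it gives a 1.4-fold lower number from compound 3 to compound 4 (0.14 log units; within the scatter) and a 1.4-fold lower number from compound 2 to compound 4 (0.14 log units; within the scatter) when it replaces the other two substituents, with a 1.5-fold lower number from compound 1 to compound 4 (0.16 log units; within the scatter) against the unsubstituted ring. These are larger steps than the earlier ones at this position, yet each still lies within the scatter, so hydrogen, methoxy, methyl and fluoro on this carbon cannot be told apart in this read-out, and 4-fluorophenyl extends the flat picture rather than breaking it. No measurement offered here speaks to why compound 4 gives the number it does.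

Going by these compounds, all four compounds vary only this one carbon, so it stays open whether an amine or a carboxylic acid there would give a step beyond the scatter in this assay. Also open, on these data alone, is what a longer chain would do elsewhere on the shared core, where these compounds show no variation at all.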